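The source may report more compounds than this note shows. Statements on the series, on what has been measured and on what is new or still open speak of the compounds shown alone.

In an ADME assay on HaCaT cells (Homo sapiens) for cytotoxicity, read by MTT assay, with a stated time of 72 h (a lower number here means a stronger inhibitor, a higher number a weaker inhibitor), compound 2 `COc1ccc(-n2nnnc2Nc2ccccc2F)cc1` gives 111000 nM, and compound 1 `COc1ccc(-n2nnnc2Nc2ccccc2Br)cc1` gives 137000 nM; the two stand level within the scatter, so neither can be set apart from the other. Among the compounds with values here, the only measured step, a 1.2-fold lower number from compound 1 to compound 2 (0.09 log units; within the scatter), exchanges one halogen for another on an aromatic carbon. Compound 3 `COc1ccc(-n2nnnc2Nc2ccc(Cl)cc2)cc1` carries 4-chlorophenyl in place of 2-fluorophenyl on a nitrogen on an aromatic ring. Within the data shown here, that single step is the only guide for this change, and since it stayed within the scatter, no step beyond the scatter is expected in this assay. Compound 3 is therefore estimated at 120000 nM, ranging from 50000 nM to 280000 nM, an expected step of a 1.1-fold higher number from compound 2 to compound 3 (0.03 log units; within the scatter).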

Compound 3, half-maximal inhibitory concentration: 143000 nM
Compound 3: middle estimate off by 1.2-fold (0.08 log units), on the low side, within the range that was stated.
By their numbers in this assay, from the lowest: compounds 2, 1 and 3 (each within the scatter of the next).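

In this assay, within the data shown here, the earlier compounds showed only one halogen exchanged for another, whereas here the halogen and its printed ring number both differ: 4-chlorophenyl in place of 2-fluorophenyl gives a 1.3-fold higher number from compound 2 to compound 3 (0.11 log units; within the scatter), and 4-chlorophenyl in place of 2-bromophenyl gives a 1.0-fold higher number from compound 1 to compound 3 (0.02 log units; within the scatter). Among these three compounds, then, the change of halophenyl group on this nitrogen leaves the number within the scatter. No supporting measurement bears on this result. Still open, going by these compounds, is whether a phenyl group carrying an amine or a carboxylic acid would move the number beyond the scatter.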